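Moving the hydroxycarbamoyl group on the phenyl of compound 2

The source may hold more compounds than are shown below. What is called first, only, known or untested is meant among the compounds shown, and "the series" means these compounds.

The series is read in an assay on Sf9 cells for inhibition of histone deacetylase 11 (Homo sapiens), read by fluorescence, tested at 0.5 uM; a lower number here means less inhibition, a higher number more inhibition at the concentration tested (going by the name of the read-out). Compound 2, `O=C(NO)c1cccc(-c2cn([C@H]3C[C@@H](CO)N(CCCc4ccccc4)C3)nn2)c1`, stands only at a limit of the assay: in this assay compound 2 gives < 10%. Compound 1, `O=C(NO)c1ccc(-c2cn([C@H]3C[C@@H](CO)N(Cc4ccccc4)C3)nn2)cc1`, likewise gives only a limit, < 10%, in this assay. Compound 3, `O=C(NO)c1cccc(-c2cn([C@H]3C[C@@H](C(=O)O)N(CCCc4ccccc4)C3)nn2)c1`, also stays at the limit of this assay with < 10%. Within the data shown here, the one single-point step among the measured compounds, a step that the two limits leave unreadable from compound 2 to compound 3, cannot be sized because of the limit of < 10% in this assay, at which 3 of the 3 values shown sit.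

Compound 4, `O=C(NO)c1ccc(-c2cn([C@H]3C[C@@H](CO)N(CCCc4ccccc4)C3)nn2)cc1`, is compound 2 with 4-(hydroxycarbamoyl)phenyl in place of 3-(hydroxycarbamoyl)phenyl on an aromatic carbon. Among the measured compounds shown here, no measured step bears directly on this change; the only recorded step, from compound 2 to compound 3, sits between two limits, and every value in the set rests at the same limit, so there is no measured movement to extrapolate from. Compound 4 is therefore expected to stay at the limit of this assay, with the expected step that the limit leaves unreadable from compound 2 to compound 4 amounting to nothing beyond the scatter. The estimate for compound 4 in this assay is 5%, ranging from 0% to 15%, most likely reported again only as a limit.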

Compound 4, a percentage reported as inhibition, at one concentration (the size of the read-out at that concentration, not a potency): < 10%
Compound 4: no number, only a limit (the forecaster's own chance of this, stated with the estimate: 85%); the middle value does not contradict the limit.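

In this assay compound 4 gives < 10%, which is a limit of the assay. Neither the step to compound 4 from compound 2 nor the step to it from compound 1 can be sized, because all the values rest at one limit: the limit of < 10% in this assay, at which 4 of the 4 values shown sit.

The compounds shown leave open whether 4-(hydroxycarbamoyl)phenyl or 3-(hydroxycarbamoyl)phenyl makes any difference to inhibition.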